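Trifluoromethyl for ethyl on a sulfonyl sulfur: a repeated step

The source may hold more compounds than are shown below. What is called first, only, known or untested is meant among the compounds shown, and "the series" means these compounds.

Compound 1 `CCS(=O)(=O)Nc1ccc(NC(=O)c2ccc(Cl)cc2)cc1C` gives 68700 nM in an ADME assay on RAW264.7 cells (Mus musculus) for cytotoxicity, read by MTT assay, with a stated time of 48 h; a lower number here means a stronger inhibitor, a higher number a weaker inhibitor. Compound 2 `Cc1cc(NC(=O)c2ccc(Cl)cc2)ccc1NS(=O)(=O)C(F)(F)F` carries trifluoromethyl in place of ethyl on a sulfonyl sulfur and gives 35400 nM in this assay; the step is a 1.9-fold lower number from compound 1 to compound 2 (0.29 log units; within the scatter). Compound 3 `CCS(=O)(=O)Nc1ccc(NC(=O)c2ccc(Cl)cc2)cc1OC` carries methoxy in place of methyl on an aromatic carbon relative to compound 1; in this assay compound 3 gives 60100 nM, a step of a 1.1-fold lower number from compound 1 to compound 3 (0.06 log units; within the scatter).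

Compound 4 `COc1cc(NC(=O)c2ccc(Cl)cc2)ccc1NS(=O)(=O)C(F)(F)F` has not yet been measured. It differs from compound 3 by trifluoromethyl in place of ethyl on a sulfonyl sulfur, and the two cores differ by methoxy in place of methyl on an aromatic carbon. Since the change around the sulfonyl sulfur is described in the same words for both pairs, it is the same change made on a core that differs only in the way just stated.

Within the data shown here, compound 4 is therefore expected to show a step of a 1.9-fold lower number from compound 3 to compound 4 (0.27 log units; within the scatter) in this assay, of about the size of a 1.9-fold lower number from compound 1 to compound 2 (0.29 log units; within the scatter), an expectation that rests on compound 1 and compound 2 because a 1.9-fold lower number from compound 1 to compound 2 (0.29 log units; within the scatter) is the only example of this change measured so far. The estimate for compound 4 is 32000 nM, with a range from 15000 nM to 70000 nM.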

Compound 4, half-maximal inhibitory concentration: 108000 nM
Estimate against measurement, compound 4: 3.4-fold (0.53 log units) below; measured number outside the range, above it.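

In this assay, trifluoromethyl in place of ethyl on a sulfonyl sulfur did not give the same step on the core of compound 3 as on the core of compound 1, and the two steps stand further apart than their scatter allows: the same change on two cores in this assay, a 1.9-fold lower number (0.29 log units; within the scatter) from compound 1 to compound 2 and a 1.8-fold higher number (0.25 log units; within the scatter) from compound 3 to compound 4, 3.5-fold (0.54 log units) apart, beyond the scatter of two such steps. Seen from the other side of the same four compounds, methoxy in place of methyl on an aromatic carbon gives a 3.1-fold higher number from compound 2 to compound 4 (0.48 log units; beyond the scatter) where the sulfonyl sulfur carries trifluoromethyl, which does not match the step seen where it carries ethyl: the same change on two cores in this assay, a 1.1-fold lower number (0.06 log units; within the scatter) from compound 1 to compound 3 and a 3.1-fold higher number (0.48 log units; beyond the scatter) from compound 2 to compound 4, 3.5-fold (0.54 log units) apart, beyond the scatter of two such steps. This shows that the two changes do not simply add up in these four compounds, but a 1.8-fold higher number from compound 3 to compound 4 (0.25 log units; within the scatter) does not establish a direction for the trifluoromethyl step on its own, and a single set of four compounds cannot show why the steps differ or how far this extends.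

On these data alone, it remains open whether the same mismatch appears with a longer chain on the sulfonyl sulfur, such as propyl. The same question stands for other groups on the aromatic carbon, such as an amine or a chlorine.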